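Methyl in Place of Hydrogen on Compound 1

The source may report more compounds than this note shows. Statements on the series, on what has been measured and on what is new or still open speak of the compounds shown alone.

compound 1 `COc1ccc(/C=C/c2cc(OC)cc(OC)c2/C=C/C(=O)c2ccccc2)cc1`: 3.7 ug/mL
compound 2 `COc1ccc(/C=C/c2cc(OC)cc(OC)c2/C=C/C(=O)c2ccc(Br)cc2)cc1`: 6.5 ug/mL

In a functional assay on B16-F10 cells (Mus musculus) for antiproliferative activity, read by MTT assay, with a stated time of 48 h (on this read-out lower numbers stand for stronger inhibition and higher numbers for weaker inhibition), compound 1 gives 3.7 ug/mL, the lowest of the two numbers shown, while compound 2 gives 6.5 ug/mL. Within the data shown here, the only measured step, a 1.8-fold higher number from compound 1 to compound 2 (0.24 log units; within the scatter), stays within the scatter. Compound 3 `COc1ccc(/C=C/c2cc(OC)cc(OC)c2/C=C/C(=O)c2ccc(C)cc2)cc1` differs from compound 1 by methyl in place of hydrogen on an aromatic carbon. Among the measured compounds shown here, the bromo step is the one comparison that bears on this change, and it moved the number only a little. A similar outcome is therefore expected: an estimated 1.2-fold higher number from compound 1 to compound 3 (0.09 log units; within the scatter), not clearly beyond the scatter. Compound 3 is expected to give about 4.5 ug/mL, somewhere between 2 ug/mL and 10 ug/mL.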

Compound 3, half-maximal inhibitory concentration: 5.3 ug/mL
Compound 3: middle estimate off by 1.2-fold (0.07 log units), on the low side; measured number inside the range.
By their numbers in this assay, from the lowest: compounds 1, 3 and 2 (each within the scatter of the next).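

Methyl on this aromatic carbon, para to a large group, gives a second reading of a change at this spot in this assay: there is a 1.4-fold higher number from compound 1 to compound 3 (0.16 log units; within the scatter) and also a 1.2-fold lower number from compound 2 to compound 3 (0.09 log units; within the scatter), and both steps lie within the scatter. Hydrogen, bromo and methyl therefore cannot be told apart here, so this position has so far tolerated all three groups shown. Nothing at hand offers a reason for these small steps. As far as these compounds go, whether an amine, a carboxylic acid or a longer chain such as butyl on this carbon would give a step beyond the scatter remains open.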